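Removing the para methoxy from the triazole series

A few compounds are considered here, and "the series" means these few. Any claim that something is new, unique, unknown or untested is made for them only; others in the source may bear on it.

Measured compounds:
compound 1 `COc1cc(-n2ncnc2-c2ccc(C)cc2)cc(OC)c1OC` — 250 nM
compound 2 `COc1cc(-n2ncnc2-c2cccc(F)c2)cc(OC)c1OC` — > 10000 nM (a limit of the assay)
compound 3 `COc1ccc(-c2ncnn2-c2cc(OC)c(OC)c(OC)c2)cc1` — 280 nM

In a functional assay on HeLa cells (Homo sapiens) for antiproliferative activity, read by MTT assay, with a stated time of 72 h (a lower number here means a stronger inhibitor, a higher number a weaker inhibitor), compound 3 gives 280 nM, the highest of the two numbers shown, yet a 1.1-fold higher number from compound 1 to compound 3 (0.05 log units; within the scatter), so compound 1 and compound 3 cannot be ordered. Compound 2 `COc1cc(-n2ncnc2-c2cccc(F)c2)cc(OC)c1OC` gives only a limit in this assay, > 10000 nM. The steps that reach it are large: an at least 40-fold higher number from compound 1 to compound 2 (1.60 log units; beyond the scatter) and an at least 35-fold lower number from compound 2 to compound 3 (1.55 log units; beyond the scatter), both pairing a change of group with a change of place (the limit of > 10000 nM in this assay, at which 1 of the 3 values shown sits).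

The unmeasured compound 4 `COc1cc(-n2ncnc2-c2ccccc2)cc(OC)c1OC` differs from compound 3 by hydrogen in place of methoxy on an aromatic carbon. For the measured compounds named here, no measured step removes a group outright; compound 1 and compound 3 show only that methyl and methoxy sit within the scatter of one another, while compound 2 shows that moving away from that arrangement can cost much. A loss beyond the scatter is therefore expected, but smaller than the step to compound 2: compound 4 is estimated at 3000 nM, within 500 nM to 10000 nM, which would mean an 11-fold higher number from compound 3 to compound 4 (1.03 log units; beyond the scatter).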

Compound 4, half-maximal inhibitory concentration: > 10000 nM
Compound 4: no number, only a limit; the forecaster's own chance of this, stated with the estimate: 25%; middle value at least 3.3-fold (0.52 log units) away from the limit.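

In this assay, hydrogen in place of methoxy gives an at least 35-fold higher number from compound 3 to compound 4 (1.55 log units; beyond the scatter), and hydrogen in place of methyl gives an at least 40-fold higher number from compound 1 to compound 4 (1.60 log units; beyond the scatter). Methyl and methoxy could not be told apart at this place, para to a large group, but the loss of either one is large, so among these compounds the activity depends on a group being present there, not on which of the two it is. The step between compound 2 and compound 4, hydrogen in place of fluoro, cannot be read, because both values are limits: the limit of > 10000 nM in this assay, at which 2 of the 4 values shown sit.

On these data alone, it remains open whether another group at this place, such as an amine, a chlorine atom or an ethyl group, would hold the activity of compound 1 and compound 3. As far as these compounds go, it is also open how far the values of compound 2 and compound 4 lie beyond their limits.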